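This account rests on a few compounds, and the source may have more. Where it says the series, first, only, none or still open, it means among the compounds named here.

Among the compounds with values here, compound 3 `O=S(=O)(c1cccc(Cl)c1)c1cn(C2CCCNC2)c2ncccc12` is one of three compounds measured in a functional assay on HeLa cells for agonist activity at 5-hydroxytryptamine receptor 6 (Homo sapiens), read by cAMP accumulation and immunoassay; a higher number here means a larger maximal response, a lower number a smaller maximal response. It gives 49%, which is the second highest of the three numbers. Within the data shown here, compound 2 `O=S(=O)(c1ccccc1Cl)c1cn(C2CCCNC2)c2ncccc12` gives 84% in this assay, and compound 1 `O=S(=O)(c1cccc(F)c1)c1cn(C2CCNC2)c2ncccc12` gives 44%; the gap from compound 1 to compound 3 lies within the usual scatter, while the single step that is recorded, a number 35 percentage points lower from compound 2 to compound 3 (beyond the scatter), lies well beyond it.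

Compound 4 `O=S(=O)(c1cccc(F)c1)c1cn(C2CCCNC2)c2ncccc12` is not yet measured. It differs from compound 3 in one place: fluoro in place of chloro on an aromatic carbon. Among the measured compounds shown here, none of the measured steps carries this same exchange; the only recorded step, a number 35 percentage points lower from compound 2 to compound 3 (beyond the scatter), moves chloro from one position to another and so has no direct bearing on a swap of chloro for fluoro. What the numbers do show is that compound 1, which already carries the 3-fluorophenyl group on its own core, sits within the scatter of compound 3 in this assay. Compound 4 is therefore expected to show a step of a number 2 percentage points lower from compound 3 to compound 4 (within the scatter), that is, nothing beyond the scatter. The estimate for compound 4 in this assay is 47%, with a range from 30% to 65%.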

Compound 4, largest response reached (Emax), in percent of the reference or control that the assay uses: 84%
Beside the measured number, compound 4's estimate is 37 percentage points below it, and the stated range ends below it.
By their numbers in this assay, from the lowest: compounds 1 and 3 (each within the scatter of the next); then compounds 2 and 4 (each within the scatter of the next).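

In this assay, within the data shown here, fluoro in place of chloro on this aromatic carbon, meta to a large group, gives a number 35 percentage points higher from compound 3 to compound 4 (beyond the scatter) and so shows that the choice of halogen here matters, which no earlier step could reveal. On the aromatic nitrogen, piperidin-3-yl in place of pyrrolidin-3-yl gives a number 40 percentage points higher from compound 1 to compound 4 (beyond the scatter) while the 3-fluorophenyl group stays the same, so the ring at that nitrogen matters as well. Among these compounds, on the sulfonyl sulfur, 3-fluorophenyl in place of 2-chlorophenyl gives no change at the digits printed from compound 2 to compound 4 (within the scatter) and leaves 3-chlorophenyl as the one group of these three with the smaller response on the shared core.

Nothing on hand explains the gain from chloro to fluoro. Going by these compounds, it also remains open whether a methoxy, nitrile or trifluoromethyl group on this carbon would behave like fluoro or like chloro.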